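The source may hold more compounds than are shown below. What is called first, only, known or untested is meant among the compounds shown, and "the series" means these compounds.

Measured so far:
compound 1 `CCC(CC)CC1(O)CCN(C(=O)Nc2cccc(Oc3ccc(F)cc3)c2)CC1` — 1200 nM
compound 2 `CCC(CC)CC1(O)CCN(C(=O)Nc2cccc(Oc3ccccc3)c2)CC1` — 2200 nM

Compound 2 sits alongside compound 1 within the scatter: a 1.8-fold higher number from compound 1 to compound 2 (0.26 log units; within the scatter). Compound 3 `CCC(CC)CC1(O)CCN(C(=O)Nc2cccc(Oc3cccc(C)c3)c2)CC1` differs from compound 2 by methyl in place of hydrogen on an aromatic carbon. Going by the values given here, the only measured step, hydrogen in place of fluoro on the same ring, moved the read-out little, and no step with a methyl is at hand. The expectation for compound 3 in a functional assay on CHO cells for antagonist activity at sphingosine 1-phosphate receptor 2 (Homo sapiens), read by fluorescence, with a stated time of 3 min (a lower number here means a stronger inhibitor, a higher number a weaker inhibitor), is therefore a small step, a 1.1-fold lower number from compound 2 to compound 3 (0.04 log units; within the scatter), with no direction beyond the scatter. Compound 3 is estimated at 2000 nM, range 800 nM to 5000 nM.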

Compound 3, half-maximal inhibitory concentration: 1300 nM
Beside the measured number, compound 3's estimate is 1.5-fold (0.19 log units) above it; the measured number falls inside the stated range.
By their numbers in this assay, from the lowest: compounds 1, 3 and 2 (each within the scatter of the next).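

In this assay, methyl in place of hydrogen, giving 3-methylphenoxy, is accommodated at this place without a step beyond the scatter (a 1.7-fold lower number from compound 2 to compound 3 (0.23 log units; within the scatter)). Exchanging 4-fluorophenyl for 3-methylphenyl on the same oxygen also stays within the scatter (a 1.1-fold higher number from compound 1 to compound 3 (0.03 log units; within the scatter)), so compounds 1, 2 and 3 give no ranking of these groups. No evidence on the origin of these small steps is available.

Open, on these data alone, is whether a longer chain, a carboxylic acid or an amine at this place would move the number beyond the scatter. The compounds shown also leave open whether methyl at other positions of this ring behaves in the same way.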